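Compound 3: swapping the carbamate for a ring

A few compounds are considered here, and "the series" means these few. Any claim that something is new, unique, unknown or untested is made for them only; others in the source may bear on it.

Measured in a functional assay on aorta (Rattus norvegicus, strain Sprague-Dawley); a lower number here means that less compound is needed, a higher number that more compound is needed for the effect:
- compound 1 `Cc1nn(-c2ccccc2)c2nc(OCc3ccccc3F)c(-c3nc(N)c(N4CCCCC4)c(N)n3)cc12` gives 790 nM
- compound 2 `COC(=O)Nc1c(N)nc(-c2cc3c(C)nn(-c4ccccc4)c3nc2OCc2ccccc2F)nc1N` gives 5800 nM

Of these two numbers, the higher belongs to compound 2 at 5800 nM. Compound 3 `Cc1nn(-c2ccccc2)c2nc(OCc3ccccc3F)c(-c3nc(N)c(N4CCOC4=O)c(N)n3)cc12` differs from it in one place, with 2-oxo-1,3-oxazolidin-3-yl in place of (methoxycarbonyl)amino on an aromatic carbon. Within the data shown here, one measured step bears on this place: a 7.3-fold higher number from compound 1 to compound 2 (0.87 log units; beyond the scatter), with (methoxycarbonyl)amino replacing piperidin-1-yl. The group entering compound 3 is a ring, as is the piperidin-1-yl of compound 1 at 790 nM, so a partial move back toward that lower number in this assay is expected. Among the measured compounds shown here, no measured compound carries this ring, so the direction remains uncertain. The estimated change is a 2.3-fold lower number from compound 2 to compound 3 (0.37 log units; beyond the scatter), smaller than the measured step. The estimate for compound 3 is 2500 nM, with an expected range of 600 nM to 10000 nM.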

Compound 3, half-maximal effective concentration: > 100000 nM
Compound 3 ended at the assay's limit; the forecaster's own chance of this, stated with the estimate: 5%; middle value at least 40-fold (1.60 log units) from the limit.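

In this assay, compound 3 gives > 100000 nM, which is a limit of the assay and not a number. Having a ring at this place, ortho to two amino groups, is therefore not enough to return toward the lower number: replacing piperidin-1-yl with 2-oxo-1,3-oxazolidin-3-yl gives an at least 120-fold higher number from compound 1 to compound 3 (2.10 log units; beyond the scatter). Closing the open (methoxycarbonyl)amino group into this ring, with 0 hydrogen-bond donors in place of 1, also moves the number the wrong way, giving an at least 17-fold higher number from compound 2 to compound 3 (1.23 log units; beyond the scatter).

From the compounds shown here alone, it remains open whether the ring carbonyl, the ring oxygen, or the missing hydrogen-bond donor accounts for this difference. A ring amine without a carbonyl, such as pyrrolidin-1-yl or morpholin-4-yl, would show whether values near that of compound 1 at 790 nM extend beyond piperidin-1-yl.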